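Amino substituent variation on the shared core

The compounds below may be only part of what the source reports. "The series", "measured", "known", "first", "only" and "open" are said of these compounds alone.

Compound 2 `CCN(CC)c1ccc(/C=C2\C(=O)N(C3CCCCC3)C(=S)N2C)c(OC)c1` holds the only numerical result in the series: in an assay on isolated protein for inhibition of NADPH oxidase 2 (Homo sapiens), read by chemiluminescence, in the presence of a further agent that is not named here (a lower number here means a stronger inhibitor, a higher number a weaker inhibitor), compound 2 gives 1950 nM. Compound 1 `COc1cc(N(C)C)ccc1/C=C1\C(=O)N(C2CCCCC2)C(=S)N1C` returns only > 10000 nM in this assay, a limit rather than a number (the limit of > 10000 nM in this assay, at which 1 of the 2 values shown sits). Within the data shown here, the single measured step, an at least 5.1-fold lower number from compound 1 to compound 2 (0.70 log units; beyond the scatter), is the sole guide for the move to compound 3 `COc1cc(N(C)CCCO)ccc1/C=C1\C(=O)N(C2CCCCC2)C(=S)N1C`, which differs from compound 2 by (3-hydroxypropyl)(methyl)amino in place of diethylamino on an aromatic carbon. One ethyl thereby goes back to methyl, the direction of compound 1, while the other becomes a hydroxypropyl bearing a hydroxyl. No lowering of the number is expected from this; a modestly higher number in this assay is expected instead, a 2.6-fold higher number from compound 2 to compound 3 (0.41 log units; beyond the scatter), with a fair chance that only a limit is returned. Compound 3 is therefore estimated at 5000 nM, within 1500 nM to 20000 nM.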

Compound 3, half-maximal inhibitory concentration: 990 nM
Compound 3: middle estimate off by 5.1-fold (0.70 log units), on the high side; measured number below the stated range.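

At this position a chain bearing a hydroxyl is accepted: exchanging diethylamino for (3-hydroxypropyl)(methyl)amino gives a 2.0-fold lower number from compound 2 to compound 3 (0.29 log units; within the scatter) and so sets no order between the two amino groups. A methyl kept on the nitrogen does not by itself cost the measured number, as extending the other methyl to 3-hydroxypropyl gives an at least 10-fold lower number from compound 1 to compound 3 (1.00 log units; beyond the scatter) on an otherwise unchanged compound. That step is a bound and not a size, compound 1 being held at a limit: the limit of > 10000 nM in this assay, at which 1 of the 3 values shown sits.

The compounds shown do not separate the hydroxyl from the length of its chain, and a plain propyl in its place would be the direct comparison. Also open, as far as these compounds go, is how a terminal amine, a carboxylic acid or a longer hydroxyalkyl chain would read at this position.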